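The source may report more compounds than this note shows. Statements on the series, on what has been measured and on what is new or still open speak of the compounds shown alone.

Compound 1 `O=Cc1cn(-c2ccccc2)nc1-c1ccc(Cl)cc1` — in an ADME assay on HaCaT cells (Homo sapiens) for cytotoxicity, read by MTT assay, with a stated time of 48 h (a lower number here means a stronger inhibitor, a higher number a weaker inhibitor), compound 1 gives > 50000 nM, which is a limit of the assay and not a number.
Compound 2 `c1ccc(-c2nn(-c3ccccc3)cc2-c2nc3ccccc3[nH]2)cc1` — in this assay compound 2 gives > 50000 nM, again a limit.
Compound 3 `Clc1ccc(-c2nn(-c3ccccc3)cc2-c2nc3ccccc3[nH]2)cc1` — in this assay compound 3 gives > 50000 nM, also a limit.

Compound 3 therefore stands nowhere in particular on a scale of numbers: the assay only reports that its value lies beyond the top of the measured range, as it does for the other two. The two steps that lead to compound 3, a step that the two limits leave unreadable from compound 1 to compound 3 and a step that the two limits leave unreadable from compound 2 to compound 3, cannot be sized, because the limit of > 50000 nM in this assay, at which 3 of the 3 values shown sit, covers both ends of each.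

Compound 4 `O=C(OCc1ccccc1)c1ccc2[nH]c(-c3cn(-c4ccccc4)nc3-c3ccc(Cl)cc3)nc2c1` differs from compound 3 in one place: benzyloxycarbonyl in place of hydrogen on an aromatic carbon. Among the measured compounds shown here, no measured step bears on this kind of change, and the steps that do exist give no size. With every value shown sitting at the limit, the expectation for compound 4 is no step beyond the scatter, a number no higher from compound 3 to compound 4 (the limit leaves the size open), so compound 4 is estimated at 50000 nM, within 15000 nM to 50000 nM, most likely again reported only as a limit.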

Compound 4, half-maximal inhibitory concentration: > 50000 nM
Compound 4 ended at the assay's limit (the forecaster's own chance of this, stated with the estimate: 70%); the middle value sits exactly at the limit.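

No new step can be read from compound 3 to compound 4, because both sit at the same limit of the assay: the limit of > 50000 nM in this assay, at which 4 of the 4 values shown sit.

The compounds shown leave open what true number lies behind that limit for each, and whether any change to the shared core would give a measurable value.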